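The source may report more compounds than this note shows. Statements on the series, on what has been measured and on what is new or still open speak of the compounds shown alone.

Compound 3 `Cc1ccc(-c2c(C)nc(NC(=O)NC3CCCC3)c(C)c2C(OC(C)(C)C)C(=O)O)cc1C` is the reference for this step. In an ADME assay on MT4 cells (Homo sapiens) for cytotoxicity, read by MTT assay (a lower number here means that less compound is tolerated, a higher number that more compound is tolerated), compound 3 gives 8000 nM, the highest of three numbers, though every gap to the others lies within the scatter. Compound 1 `Cc1ccc(-c2c(C)nc(NC(=O)NC3CCCCC3)c(C)c2C(OC(C)(C)C)C(=O)O)cc1C` gives 7900 nM, and compound 2 `Cc1ccc(-c2c(C)nc(Nc3nc4ccccc4s3)c(C)c2C(OC(C)(C)C)C(=O)O)cc1C` gives 6600 nM. The change to compound 4 `COc1ccc(Nc2nc(C)c(-c3ccc(C)c(C)c3)c(C(OC(C)(C)C)C(=O)O)c2C)cc1` is 4-methoxyphenyl in place of cyclopentylcarbamoyl on a nitrogen on an aromatic ring. For the measured compounds named here, two measured steps bear on it, both exchanging the group on the same nitrogen: a 1.2-fold higher number from compound 2 to compound 3 (0.08 log units; within the scatter) and a 1.2-fold lower number from compound 1 to compound 2 (0.08 log units; within the scatter); neither moved the read-out beyond the scatter. A 4-methoxyphenyl on that nitrogen is accordingly expected to leave this assay unchanged, a 1.1-fold lower number from compound 3 to compound 4 (0.06 log units; within the scatter). For compound 4 the estimate is 7000 nM, with a range of 3500 nM to 14000 nM.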

Compound 4, half-maximal cytotoxic concentration: 28000 nM
For compound 4 the middle estimate is 4.0-fold (0.60 log units) below the measured one; the measured number lies above the stated range.
By their numbers in this assay, from the lowest: compounds 2, 1 and 3 (each within the scatter of the next); then compound 4.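

For the compounds shown here, on the nitrogen on the aromatic ring, 4-methoxyphenyl is the first group to move the number in this assay beyond the scatter, by a modest amount against each earlier group (a 3.5-fold higher number from compound 3 to compound 4 (0.54 log units; beyond the scatter); a 3.5-fold higher number from compound 1 to compound 4 (0.55 log units; beyond the scatter); a 4.2-fold higher number from compound 2 to compound 4 (0.63 log units; beyond the scatter)). Cyclopentylcarbamoyl, cyclohexylcarbamoyl and 1,3-benzothiazol-2-yl remain within the scatter of one another, so the shift at this position belongs to compound 4 alone. Nothing available explains this shift.

Going by these compounds, whether the step depends on the methoxy group or on the aromatic ring remains open. An unsubstituted phenyl, or an amine or a carboxylic acid in place of the methoxy group, could separate the two.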